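A few compounds are considered here, and "the series" means these few. Any claim that something is new, unique, unknown or untested is made for them only; others in the source may bear on it.

Compound 3 `CCc1cccc(NC(=O)N[C@@H](C)c2ccccc2)c1` stands second highest of the three numbers in an ADME assay on the whole organism with Oryza sativa as the target, tested at 1 uM; a lower number here means a stronger effect, a higher number a weaker effect of the compound at the concentration tested: compound 3 gives 94%. Compound 1 `Cc1cccc(NC(=O)N[C@H](C)c2ccccc2)c1` gives 98%, within the scatter of compound 3, and compound 2 `CCc1cccc(NC(=O)N[C@H](C)c2ccccc2)c1` gives 71%, beyond it. Two steps have been measured: a number 27 percentage points lower from compound 1 to compound 2 (beyond the scatter), and a number 23 percentage points higher from compound 2 to compound 3 (beyond the scatter), a step that rests on (the fact that compounds 2 and 3 differ only in the configuration as drawn). Compound 4 `CC(=O)c1cccc(NC(=O)N[C@@H](C)c2ccccc2)c1` differs from compound 3 by acetyl in place of ethyl on an aromatic carbon. Neither measured step concerns a change on an aromatic carbon, so they offer no guide to the size or direction of this one, and no step beyond the scatter is expected in this assay, a number 4 percentage points lower from compound 3 to compound 4 (within the scatter). Compound 4 is therefore estimated at 90%, with a range from 68% to 100%.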

Compound 4, a percentage reported as activity, at one concentration (the size of the read-out at that concentration, not a potency): 95%
Beside the measured number, compound 4's estimate is 5 percentage points below it; low and high end bracket the measured number.
By their numbers in this assay, from the lowest: compound 2; then compounds 3, 4 and 1 (each within the scatter of the next).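

In this assay, among these compounds, the only step measured on an aromatic carbon, meta to a large group, lies within the scatter: a number 1 percentage points higher from compound 3 to compound 4 (within the scatter). At this position, then, acetyl, which brings a carbonyl oxygen and a hydrogen-bond acceptor, cannot be told apart from ethyl in this read-out. Nothing at hand bears on why this should be so. The compounds shown leave open whether an amine or a carboxylic acid at this place would shift the number. They also leave open whether acetyl would read the same in the configuration drawn in compound 2.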